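The source may report more compounds than this note shows. Statements on the series, on what has been measured and on what is new or still open speak of the compounds shown alone.

Measured in a functional assay (aorta) with Rattus norvegicus as the target; a higher number here means that more compound is needed for the effect, a lower number that less compound is needed:
Compound 1 `COc1ccc(-c2nc(CNC(=O)CSC)sc2-c2ccc(OC)cc2)cc1` gives 6 uM
Compound 2 `COc1ccc(-c2nc(CNC(=O)N3CCOCC3)sc2-c2ccc(OC)cc2)cc1` gives 12 uM
Compound 3 `COc1ccc(-c2nc(C(=O)N=C(N)N)sc2-c2ccc(OC)cc2)cc1` gives > 100 uM

In this assay compound 3 stands at > 100 uM, and this is a limit of the assay, not a number. The two steps that reach it both lie beyond the scatter: an at least 16-fold higher number from compound 1 to compound 3 (1.22 log units; beyond the scatter) and an at least 8.3-fold higher number from compound 2 to compound 3 (0.92 log units; beyond the scatter).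

Compound 4 `COc1ccc(-c2nc(C(=O)N3CCOCC3)sc2-c2ccc(OC)cc2)cc1` has not yet been measured. It keeps the carbonyl of compound 3 and exchanges the group on it: a group of 6 heavy atoms (4 carbon, 1 nitrogen, 1 oxygen; one six-membered non-aromatic ring with 2 hetero atoms) in place of a group of 4 heavy atoms (1 carbon, 3 nitrogen; no ring), on a carbonyl carbon. Morpholin-4-yl thus replaces a group of 4 heavy atoms (1 carbon, 3 nitrogen; no ring), on a carbonyl carbon whose other neighbours are: aromatic carbon.

Compound 2 also carries morpholin-4-yl on a carbonyl carbon, and the step that introduces it, a 2.0-fold higher number from compound 1 to compound 2 (0.30 log units; within the scatter), stays within the scatter. Among the measured compounds shown here, no measured step links compound 4 directly to another compound, so the evidence is indirect. Given compound 2 and its step of an at least 8.3-fold higher number from compound 2 to compound 3 (0.92 log units; beyond the scatter), compound 4 is expected to move back toward the measurable range, though it may not get all the way.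

The estimated step is an at least 4.0-fold lower number from compound 3 to compound 4 (0.60 log units; beyond the scatter), toward a lower number. For compound 4 the estimate is 25 uM, with an expected range from 6 uM to 100 uM.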

Compound 4, concentration for half-maximal effect: < 100 uM
Compound 4: only a limit was reported; the forecaster's own chance of this, stated with the estimate: 25%; the middle value does not contradict the limit.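

In this assay compound 4 gives < 100 uM, which is a limit of the assay and not a number. Morpholin-4-yl in place of the group of 4 heavy atoms with no ring, on a carbonyl carbon whose other neighbours are aromatic carbon, gives a number no higher from compound 3 to compound 4 (the limit leaves the size open), so this change at this position is the first one shown that leaves the carbonyl in place while exchanging the group on it. The steps from compound 1 and compound 2 to compound 4 cannot be read, and neither can the size of the step from compound 3, because compound 4 has only a limit: the limit of < 100 uM in this assay, at which 1 of the 4 values shown sits.

The compounds shown leave open where compound 4 truly lies, and so whether morpholin-4-yl directly on this carbonyl carbon performs like the longer linkage of compound 2, which gives 12 uM. They also leave open how other groups on the same carbonyl carbon would read in this assay, such as a piperidin-1-yl ring, a simple alkyl amine or a carboxylic acid in place of the amide.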